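Aryloxymethyl oxazolines: from compound 3 to compound 4

A few compounds are considered here, and "the series" means these few. Any claim that something is new, unique, unknown or untested is made for them only; others in the source may bear on it.

Measured in a functional assay on the whole organism for inhibition, with Rattus norvegicus as the target, read by paw edema, with a stated time of 30 min, at a dose of 80 mg/kg by the oral route; on this read-out higher numbers stand for a stronger effect at the one dose given and lower numbers for a weaker effect:
- compound 1 `Cc1ccccc1OCC1=NCCO1`: 55.3%
- compound 2 `Cc1cc(OCC2=NCCO2)ccc1Cl`: 77.1%
- compound 3 `Cc1cccc(OCC2=NCCO2)c1`: 64.1%

Compound 3 stands second highest of the three. Its nearest neighbour is compound 1, and the two lie within the scatter of each other, so no order between them is claimed. For the measured compounds named here, compound 2 stands highest, and the one step that exists in this set, a number 13 percentage points lower from compound 2 to compound 3 (beyond the scatter), is modest but beyond the scatter.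

Compound 4 `O=[N+]([O-])c1cccc(OCC2=NCCO2)c1` differs from compound 3 in one place: nitro in place of methyl on an aromatic carbon. Going by the values given here, no measured pair shows this exchange, or any change at this position other than the chloro-to-hydrogen step above, which concerns a different group at a different position and does not bear on it directly. The set therefore gives no ground for a directed expectation, and the step of a number 2.1 percentage points lower from compound 3 to compound 4 (within the scatter) is estimated as none beyond the scatter, with a wide range to cover either direction. The value for compound 4 is expected at 62%, between 45% and 80%.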

Compound 4, a percentage reported as inhibition, in the whole organism at one dose (the size of the read-out at that dose, not a potency): 46.5%
Beside the measured number, compound 4's estimate is 15.5 percentage points above it, and the stated range covers the measured number.
By their numbers in this assay, from the lowest: compounds 4, 1 and 3 (each within the scatter of the next, the first and the last beyond it); then compound 2.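

In this assay, for the compounds shown here, nitro in place of methyl on the aromatic carbon gives a number 17.6 percentage points lower from compound 3 to compound 4 (beyond the scatter), the first evidence on what this position accepts. The exchange is not neutral: methyl at this place gives the higher number of the two groups, so the position responds to what is placed there, and the step is modest in size. Nothing on hand accounts for the step, which therefore stands as an observation only.

Whether the lower number belongs to nitro alone remains open, as an amine, a carboxylic acid, a methoxy group and a longer alkyl chain at this place are absent from the compounds shown. Also open, going by these compounds, is whether the same exchange would give a similar step with the chloro of compound 2 in place.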